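Removing the Methyl from a Quinolone Sulfonylguanidine

The compounds below may be only part of what the source reports. "The series", "measured", "known", "first", "only" and "open" are said of these compounds alone.

Compound 1 `Cc1ccc(S(=O)(=O)NC(=N)N2CCN(c3cc4c(cc3F)c(=O)c(C(=O)O)cn4C3CC3)CC2)cc1`: 71 nM
Compound 2 `CCn1cc(C(=O)O)c(=O)c2cc(F)c(N3CCN(C(=N)NS(=O)(=O)c4ccccc4C(F)(F)F)CC3)cc21`: 71 nM
Compound 3 `CCn1cc(C(=O)O)c(=O)c2cc(F)c(N3CCN(C(=N)NS(=O)(=O)c4ccccc4Cl)CC3)cc21`: 71 nM

In a functional assay on A549 cells (Homo sapiens) for antiproliferative activity, read by MTT assay, with a stated time of 72 h (a higher number here means a weaker inhibitor, a lower number a stronger inhibitor), compound 1 stands level with compounds 2 and 3; the three values lie within the scatter of one another. Compound 4 `N=C(NS(=O)(=O)c1ccccc1)N1CCN(c2cc3c(cc2F)c(=O)c(C(=O)O)cn3C2CC2)CC1` differs from compound 1 by hydrogen in place of methyl on an aromatic carbon. Among the measured compounds shown here, the only measured single-point step, no change at the digits printed from compound 2 to compound 3 (within the scatter), also altered the substituent on that aromatic ring of carbon only and produced nothing beyond the scatter, and compound 1 with its 4-methylphenyl sits alongside compounds 2 and 3. Compound 4 is therefore expected to show no change at the digits printed from compound 1 to compound 4 (within the scatter), no shift beyond the scatter. The estimate for compound 4 is 71 nM, with a range from 35 nM to 145 nM.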

Compound 4, half-maximal inhibitory concentration: 71 nM
Compound 4: middle estimate and measured number agree at the digits printed; low and high end bracket the measured number.
By their numbers in this assay, from the lowest: compounds 1, 2, 3 and 4 (each within the scatter of the next).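

In this assay, removing the methyl from the 4-methylphenyl group gives no change at the digits printed from compound 1 to compound 4 (within the scatter), so at this place on the ring, para to a large group, the methyl can give way to hydrogen with no shift beyond the scatter. The earlier step, no change at the digits printed from compound 2 to compound 3 (within the scatter), exchanged one substituent for another, whereas this one leaves the carbon bearing only hydrogen. Nothing available explains this result. Still open, on these data alone, is whether an amine, a carboxylic acid or a longer chain such as butyl at this place would hold the value. So is whether any group here can move it beyond the scatter.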